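Pyridazin-3-yl amide in place of the cyclohexyl amide

The compounds below may be only part of what the source reports. "The series", "measured", "known", "first", "only" and "open" are said of these compounds alone.

Among the measured compounds shown here, compound 3 `O=C(Nc1ccc(Cl)cc1CN1C(=O)c2ccccc2C1=O)C1CCCCC1` gives 1500 nM in an assay on CHO cells for positive allosteric modulation of metabotropic glutamate receptor 5 (Homo sapiens), read by FLIPR (a lower number here means that less compound is needed, a higher number that more compound is needed for the effect), the lowest of the two numbers known. Compound 2 `O=C(Nc1ccc(Cl)cc1CN1C(=O)c2ccccc2C1=O)c1ccccc1C(F)(F)F` gives 5700 nM in this assay, and a 3.8-fold lower number from compound 2 to compound 3 (0.58 log units; beyond the scatter). Compound 1 `O=C(Nc1ccc(Cl)cc1CN1C(=O)c2ccccc2C1=O)c1ccccc1` returns only a limit of the assay, > 100000 nM in this assay. The steps away from it are large: an at least 17-fold lower number from compound 1 to compound 2 (1.24 log units; beyond the scatter) and an at least 66-fold lower number from compound 1 to compound 3 (1.82 log units; beyond the scatter). Both of these steps rest on the limit of > 100000 nM in this assay, at which 1 of the 3 values shown sits, and so state only a minimum size.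

Compound 4 `O=C(Nc1ccc(Cl)cc1CN1C(=O)c2ccccc2C1=O)c1cccnn1` has not yet been measured. Its change from compound 3 is pyridazin-3-yl in place of cyclohexyl on a carbonyl carbon. For the measured compounds named here, no measured step exchanges cyclohexyl for a six-membered aromatic ring with 2 hetero atoms, so no step bears on it directly. The nearest guide is the exchange of phenyl for cyclohexyl, an at least 66-fold lower number from compound 1 to compound 3 (1.82 log units; beyond the scatter), which the present change runs in the reverse sense; a 3.8-fold lower number from compound 2 to compound 3 (0.58 log units; beyond the scatter) points the same way, with a smaller size. A move to a higher number in this assay is therefore expected for compound 4, beyond the scatter, as a 13-fold higher number from compound 3 to compound 4 (1.12 log units; beyond the scatter). Compound 4 is estimated at 20000 nM, within 3000 nM to 100000 nM, with a real chance that only a limit is returned.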

Compound 4, half-maximal effective concentration: > 100000 nM
Compound 4: no number, only a limit; the forecaster's own chance of this, stated with the estimate: 35%; middle value at least 5.0-fold (0.69 log units) from the limit.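

In this assay compound 4 returns only a limit, > 100000 nM, so pyridazin-3-yl on the carbonyl carbon gives no readable number. The exchange of cyclohexyl for pyridazin-3-yl gives an at least 66-fold higher number from compound 3 to compound 4 (1.82 log units; beyond the scatter), and the exchange of 2-(trifluoromethyl)phenyl for pyridazin-3-yl gives an at least 17-fold higher number from compound 2 to compound 4 (1.24 log units; beyond the scatter); both sizes are minimum sizes only. The nitrogen-containing aromatic ring therefore does not bring back a measurable response where unsubstituted phenyl gave none, and the step between compound 1 and compound 4 cannot be read, which leaves the two groups unordered, with the limit now reached twice in the series: the limit of > 100000 nM in this assay, at which 2 of the 4 values shown sit.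

Whether the two ring nitrogens of pyridazin-3-yl make any difference relative to phenyl stays unresolved, as does whether a trifluoromethyl group on the pyridazin-3-yl ring would restore a number in the way it does on phenyl in an at least 17-fold lower number from compound 1 to compound 2 (1.24 log units; beyond the scatter). Also open, going by these compounds, is whether a saturated ring carrying nitrogen, such as piperidin-4-yl, would behave like cyclohexyl or like the aromatic rings at the limit.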